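The source may hold more compounds than are shown below. What is called first, only, known or untested is meant among the compounds shown, and "the series" means these compounds.

Compound 1 `O[C@@H](c1ccccc1)[C@H]1CO[C@H](c2ccccc2)[C@@H](C/C=C/C2CCCCC2)C1` carries a cyclohexyl on the double-bonded chain, and in a functional assay on HeLa cells (Homo sapiens) for cytotoxicity, read by WST assay, with a stated time of 48 h (on this read-out higher numbers stand for weaker inhibition and lower numbers for stronger inhibition), compound 1 gives 6440 nM. Compound 2 `COc1cccc(/C=C/C[C@H]2C[C@@H]([C@@H](O)c3ccccc3)CO[C@@H]2c2ccccc2)c1` gives 10900 nM, and compound 3 `O=[N+]([O-])c1ccccc1/C=C/C[C@H]1C[C@@H]([C@@H](O)c2ccccc2)CO[C@@H]1c1ccccc1` gives 11800 nM; the steps of a 1.8-fold higher number from compound 1 to compound 3 (0.26 log units; within the scatter) and a 1.1-fold higher number from compound 2 to compound 3 (0.03 log units; within the scatter) both fall within the scatter, so these three numbers cannot be ranked. Compound 4 `O[C@@H](c1ccccc1)[C@H]1CO[C@H](c2ccccc2)[C@@H](C/C=C/c2ccccc2)C1` differs from compound 3 by hydrogen in place of nitro on an aromatic carbon. Among the measured compounds shown here, the steps that bear on such a swap on this chain, a 1.7-fold higher number from compound 1 to compound 2 (0.23 log units; within the scatter) and a 1.8-fold higher number from compound 1 to compound 3 (0.26 log units; within the scatter), stayed within the scatter, so no step beyond the scatter is expected here either. Compound 4 is therefore estimated at 10000 nM, with a range from 5000 nM to 20000 nM, meaning an expected step of a 1.2-fold lower number from compound 3 to compound 4 (0.07 log units; within the scatter).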

Compound 4, half-maximal inhibitory concentration: 6060 nM
The estimate for compound 4 lay 1.7-fold (0.22 log units) above the measured number; the range from low to high includes it.
By their numbers in this assay, from the lowest: compounds 4, 1, 2 and 3 (each within the scatter of the next).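

Hydrogen in place of nitro gives a 1.9-fold lower number from compound 3 to compound 4 (0.29 log units; within the scatter) in this assay and hydrogen in place of methoxy gives a 1.8-fold lower number from compound 2 to compound 4 (0.25 log units; within the scatter) while phenyl in place of cyclohexyl gives a 1.1-fold lower number from compound 1 to compound 4 (0.03 log units; within the scatter) and all three steps stay within the scatter. The unsubstituted phenyl therefore cannot be told apart from the two substituted phenyls or the cyclohexyl at this end of the chain. No measurement here accounts for this result. Still open, from the compounds shown here alone, is whether an amine or a carboxylic acid on the aromatic ring, or a longer chain, would give a step beyond the scatter.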